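A few compounds are considered here, and "the series" means these few. Any claim that something is new, unique, unknown or untested is made for them only; others in the source may bear on it.

Measured so far in a functional assay on HEK293 cells for agonist activity at Glucose-dependent insulinotropic receptor (Homo sapiens), read by a luciferase reporter; on this read-out higher numbers stand for an effect only at larger amounts of compound and lower numbers for an effect already at smaller amounts:
Compound 1, `CC#CCn1c(N2CCC[C@@H](N)C2)nc2c1c(=O)n(CCCN1CCC(c3nc(-c4ccccc4)cs3)CC1)c(=O)n2C`, gives 3130 nM.
Compound 2, `CC#CCn1c(N2CCC[C@@H](N)C2)nc2c1c(=O)n(CCCN1CCN(c3ncc(C)cn3)CC1)c(=O)n2C`, gives 2560 nM.

Compound 2 has the lowest of these two numbers in this assay, but the nearest value, that of compound 1, lies within the usual scatter of repeated measurements, so the two compounds cannot be told apart on these data. Compound 3, `CC#CCn1c(N2CCC[C@@H](N)C2)nc2c1c(=O)n(CCCN1CCN(c3ncc(F)cn3)CC1)c(=O)n2C`, has not been measured. It differs from compound 2 in one place: fluoro in place of methyl on an aromatic carbon. The change sits on the six-membered aromatic ring with two nitrogen, two atoms from the ring nitrogen and para to a large group; cut one bond further out it reads as 5-methylpyrimidin-2-yl becoming 5-fluoropyrimidin-2-yl. Within the data shown here, no step between two measured compounds covers this kind of exchange, so the data give it no direction of their own. The step in this assay is therefore expected to be a 1.1-fold higher number from compound 2 to compound 3 (0.04 log units; within the scatter), nothing beyond the scatter. Compound 3 is estimated at 2800 nM, with a range from 1200 nM to 6500 nM.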

Compound 3, half-maximal effective concentration: 1410 nM
Compound 3: the middle estimate sits 2.0-fold (0.30 log units) above what was measured; the measured number falls inside the stated range.
By their numbers in this assay, from the lowest: compounds 3, 2 and 1 (each within the scatter of the next, the first and the last beyond it).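

In this assay, the exchange of methyl for fluoro on this aromatic carbon, which turns 5-methylpyrimidin-2-yl into 5-fluoropyrimidin-2-yl, gives a 1.8-fold lower number from compound 2 to compound 3 (0.26 log units; within the scatter). Among these compounds, this is the first direct reading at this place on the ring, as compounds 1 and 2 differ in more than one place and offered no such comparison. The step stays within the usual scatter of repeated measurements, so compound 2 and compound 3 cannot be told apart, and this one-atom exchange leaves the read-out without a change that can be separated from noise; the data shown offer nothing that could explain the size of the step.

On these data alone, a single exchange says little about how much this position accepts overall, and it remains open whether a larger or different group on the same carbon, such as chloro, methoxy, a nitrile or an amine, would produce a step beyond the scatter. Also open, as far as these compounds go, is whether a ring carbon carrying only hydrogen there would read any differently from methyl or fluoro.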